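The source may hold more compounds than are shown below. What is called first, only, known or untested is meant among the compounds shown, and "the series" means these compounds.

Measured in an in vitro ADME assay on microsomes from liver (Simiiformes); a higher number here means that the compound lasts longer, a lower number that the compound disappears faster:

- compound 1 `CCc1cc(CCCOc2c(C)cc(-c3noc(C)n3)cc2C)on1`: 0.183 h
- compound 2 `CCOc1cc(CCCOc2c(C)cc(-c3noc(C4CC4)n3)cc2C)on1`: > 2.5 h (a limit of the assay, not a number)
- compound 3 `Cc1cc(CCCOc2c(C)cc(-c3noc(C(N)=O)n3)cc2C)on1`: 2.3 h

Of the two true numbers, compound 3 holds the higher, and compound 1 lies lower by more than the scatter. Compound 4 `Cc1cc(CCCOc2c(C)cc(-c3noc(C(C)(F)F)n3)cc2C)on1` differs from compound 3 in one place, with 1,1-difluoroethyl in place of carbamoyl on an aromatic carbon. Within the data shown here, no measured pair shows this change, so the expectation is loose. The step expected is a 1.5-fold lower number from compound 3 to compound 4 (0.19 log units; within the scatter), slightly downward but within the scatter. A wide range is still needed, since compound 1 gives 0.183 h and shows how short the half-life can be in this set. For compound 4 the estimated half-life is 1.5 h, with an expected range of 0.5 h to 3 h.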

Compound 4, half-life: 1.1 h
Compound 4: the middle estimate sits 1.4-fold (0.13 log units) above what was measured, within the range that was stated.
By their numbers in this assay, from the lowest: compound 1; then compound 4; then compound 3. At a limit, above all of these: compound 2.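

In this assay, among these compounds, the step of a 2.1-fold lower number from compound 3 to compound 4 (0.32 log units; beyond the scatter) is the first measured change at this place on the ring. Carbamoyl, with a hydrogen-bond donor and acceptor, can give way to 1,1-difluoroethyl, with neither, at a modest loss of half-life. This is one pair, however, so it sets no pattern.

From the compounds shown here alone, whether an amine, a carboxylic acid or a longer chain here would last as long remains open, as does whether this step holds with the ethyl or ethoxy of the other compounds. Nothing shown explains why the half-life falls.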